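The source may hold more compounds than are shown below. What is called first, only, known or untested is meant among the compounds shown, and "the series" means these compounds.

For the measured compounds named here, compound 1 (`[N-]=[N+]=NC[C@H]1O[C@H](CO)[C@@H](O)[C@H](O)[C@H]1O`) is the weakest-looking of the three compounds measured so far: in an assay on isolated protein (Sus scrofa) for inhibition of glycogen phosphorylase, brain form (Homo sapiens) (on this read-out higher numbers stand for weaker inhibition and lower numbers for stronger inhibition), compound 1 gives 25100000 nM, the highest number of the set. Going by the values given here, compound 2 (`[N-]=[N+]=NC[C@@H]1O[C@H](CO)[C@@H](O)[C@H](O)[C@H]1O`) has the same atoms and bonds, and in this assay compound 2 gives 15800000 nM; the step of a 1.6-fold lower number from compound 1 to compound 2 (0.20 log units; within the scatter) is the one change that can be pointed to here, namely (the fact that one of compounds 1 and 2 is drawn with a defined configuration and the other without, at the place where they differ). Compound 3 (`NCC[C@@H]1O[C@H](CO)[C@@H](O)[C@H](O)[C@H]1O`) carries aminomethyl in place of azido, and in this assay compound 3 gives 5010000 nM, a step of a 3.2-fold lower number from compound 2 to compound 3 (0.50 log units; beyond the scatter).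

Compound 4 (`CNNC(=O)[C@H]1O[C@H](CO)[C@@H](O)[C@H](O)[C@H]1O`) differs from compound 1 in one place: (methylamino)carbamoyl in place of azidomethyl on a saturated ring carbon. Among the compounds with values here, no measured step swaps one group for a wholly different one at that ring carbon; the closest guide is the modest gain seen in a 3.2-fold lower number from compound 2 to compound 3 (0.50 log units; beyond the scatter) when the group on that carbon was altered, while a 1.6-fold lower number from compound 1 to compound 2 (0.20 log units; within the scatter) shows that small changes there can also stay within the scatter. A modest step toward a lower number is therefore expected for compound 4, of about an 8.4-fold lower number from compound 1 to compound 4 (0.92 log units; beyond the scatter). On that basis compound 4 is estimated at 3000000 nM in this assay, with a range from 500000 nM to 20000000 nM.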

Compound 4, inhibition constant: 2000000 nM
Compound 4: middle estimate off by 1.5-fold (0.18 log units), on the high side, within the range that was stated.
By their numbers in this assay, from the lowest: compound 4; then compound 3; then compounds 2 and 1 (each within the scatter of the next).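

In this assay, for the compounds shown here, the step of a 13-fold lower number from compound 1 to compound 4 (1.10 log units; beyond the scatter) is large, and it is the first one here in which the whole group on this saturated ring carbon, next to the ring oxygen, is replaced. Compounds 1, 2 and 3 showed only smaller changes at this place: a change of configuration at the ring carbon that stayed within the scatter, and a modest step when the azido end of the side chain gave way to an amine. Compound 4 now shows that this position accepts a quite different group, with a carbonyl in the chain and hydrogen-bond donors going from 0 to 2, and that the number falls rather than rises with this exchange.

As far as these compounds go, the exchange alters several things at once, so it remains open whether the carbonyl or the methylamino end matters more, a question that a plain carbamoyl group, a carboxylic acid or a longer chain on the same ring carbon could help to settle. Nothing given here accounts for the size of this step.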